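Replacing the acid chain of compound 2 with a cyclopropyl amide

The source may report more compounds than this note shows. Statements on the series, on what has been measured and on what is new or still open speak of the compounds shown alone.

This account concerns two measured compounds and a third one that awaits testing. Compound 1 `Cc1nc(-c2ccc(C(F)(F)F)cc2)sc1CNc1ccc(CCC(=O)O)cc1` in a functional assay on CHO cells for agonist activity at Free fatty acid receptor 1 (Homo sapiens), read by a luciferase reporter (on this read-out lower numbers stand for smaller maximal responses and higher numbers for larger maximal responses), gives 108%. Compound 2 `Cc1nc(-c2ccc(C(F)(F)F)cc2)sc1CNc1ccc(C(C)CC(=O)O)cc1` in this assay gives 109%. Among the compounds with values here, the single measured step, a number 1 percentage points higher from compound 1 to compound 2 (within the scatter), was within the scatter. Compound 2 thus stands at the highest of the two numbers, yet within the scatter of compound 1, so no order between them is claimed.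

Compound 3 `Cc1nc(-c2ccc(C(F)(F)F)cc2)sc1CNc1ccc([C@H]2C[C@@H]2C(=O)NC2CCNC2)cc1` differs from compound 2 in one place: 2-((pyrrolidin-3-yl)carbamoyl)cyclopropyl in place of 1-(carboxymethyl)ethyl on an aromatic carbon. Within the data shown here, the only measured step concerns a methyl in place of hydrogen on a saturated chain carbon and bears little on this far larger exchange. Among the measured compounds shown here, no measured pair shows what happens when the acid-bearing chain is removed, so the expectation is uncertain. Compound 3 is expected to give 80%, a range from 30% to 115%, which would mean an expected a number 29 percentage points lower from compound 2 to compound 3 (beyond the scatter).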

Compound 3, largest response reached (reported as percent of maximum), in percent of the reference or control that the assay uses: 52%
Compound 3: the middle estimate sits 28 percentage points above what was measured; low and high end bracket the measured number.
By their numbers in this assay, from the lowest: compound 3; then compounds 1 and 2 (each within the scatter of the next).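

In this assay, the position on an aromatic carbon, para to a large group, now shows a change the methyl step did not: putting 2-((pyrrolidin-3-yl)carbamoyl)cyclopropyl there gives a number 57 percentage points lower from compound 2 to compound 3 (beyond the scatter), and in place of 2-carboxyethyl it gives a number 56 percentage points lower from compound 1 to compound 3 (beyond the scatter). The response is reduced but not lost, since compound 3, whose entering group carries no carboxylic acid, still gives 52%. Nothing measured here offers a reason for this drop.

The compounds shown leave open which part of the entering group goes with the lower number, as the cyclopropyl ring, the amide and the pyrrolidine all enter together. They also leave open how a cyclopropyl ring bearing a carboxylic acid, or an amide with a methyl on its nitrogen in place of the pyrrolidine, would read in this assay.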